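Chain extension from compound 3 to compound 4

A few compounds are considered here, and "the series" means these few. Any claim that something is new, unique, unknown or untested is made for them only; others in the source may bear on it.

In a functional assay on HL-60 cells (Homo sapiens) for antiproliferative activity, read by MTT assay, with a stated time of 48 h (a lower number here means a stronger inhibitor, a higher number a weaker inhibitor), compound 3 `CN(C)CCn1c(N)c(-c2nc3cc(Cl)ccc3[nH]2)c2nc(C#N)c(C#N)nc21` gives > 50000 nM, which is a limit and not a number. Compound 1 `CN(C)CCCn1c(N)c(-c2nc3ccccc3[nH]2)c2nc(C#N)c(C#N)nc21` gives 870 nM and compound 2 `CN(C)CCCn1c(N)c(-c2nc3ccccc3n2C)c2nc(C#N)c(C#N)nc21` gives 2120 nM. Compound 4 `CN(C)CCCn1c(N)c(-c2nc3cc(Cl)ccc3[nH]2)c2nc(C#N)c(C#N)nc21` follows from compound 3 by (dimethylamino)methyl in place of dimethylamino on a saturated chain carbon, two bonds along the chain from an aromatic nitrogen. Among the compounds with values here, the only measured step, a 2.4-fold higher number from compound 1 to compound 2 (0.39 log units; beyond the scatter), is methyl in place of hydrogen on an aromatic nitrogen, a different change that bears on this one only loosely. The closer guide is compound 1 at 870 nM, which carries the same 3-(dimethylamino)propyl chain as compound 4 but no chloro group. A large move towards a lower number is therefore expected in this assay, estimated as an at least 33-fold lower number from compound 3 to compound 4 (1.52 log units; beyond the scatter). For compound 4 the estimated value is 1500 nM, with an expected range of 300 nM to 10000 nM.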

Compound 4, half-maximal inhibitory concentration: 2930 nM
For compound 4 the middle estimate is 2.0-fold (0.29 log units) below the measured one; measured number inside the range.
By their numbers in this assay, from the lowest: compound 1; then compounds 2 and 4 (each within the scatter of the next). At a limit, above all of these: compound 3.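

In this assay, within the data shown here, going from 2-(dimethylamino)ethyl to 3-(dimethylamino)propyl gives an at least 17-fold lower number from compound 3 to compound 4 (1.23 log units; beyond the scatter), so this chain position, untouched among the earlier compounds, carries a large effect when the chloro group is present. The size of that step is only a bound, and compound 3 is a limit and not a number: the limit of > 50000 nM in this assay, at which 1 of the 4 values shown sits. Chloro in place of hydrogen on an aromatic carbon gives a 3.4-fold higher number from compound 1 to compound 4 (0.53 log units; beyond the scatter), while 5-chloro-1H-benzimidazol-2-yl in place of 1-methyl-1H-benzimidazol-2-yl gives a 1.4-fold higher number from compound 2 to compound 4 (0.14 log units; within the scatter).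

Open, going by these compounds, is whether the chain step holds without the chloro group. Also open, on these data alone, is how a longer chain, such as 4-(dimethylamino)butyl, or a morpholine at the chain end would read.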